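The source may hold more compounds than are shown below. What is called first, only, known or untested is meant among the compounds shown, and "the series" means these compounds.

In an assay on HEK293 cells for inhibition of Fatty-acid amide hydrolase 1 (Homo sapiens), read by fluorescence (a lower number here means a stronger inhibitor, a higher number a weaker inhibitor), compound 1 `c1cc2cc(-c3ccc4oc(NC5CCCCC5)nc4c3)cnc2[nH]1` gives only a limit, > 1000 nM. Going by the values given here, compound 2 `Cn1ccc2cc(-c3ccc4oc(Cc5ccccc5)nc4c3)ccc21` is the sole compound here with a measured number, and in this assay compound 2 gives 488 nM. The not yet measured compound 3 `Cn1ccc2cc(-c3ccc4oc(N5CCn6cccc6C5)nc4c3)ccc21` differs from compound 2 in one place: a group of 9 heavy atoms (7 carbon, 2 nitrogen; one five-membered aromatic ring with 1 hetero atom, one six-membered non-aromatic ring with 2 hetero atoms) in place of a group of 7 heavy atoms (7 carbon; one six-membered aromatic ring of carbon only), on an aromatic carbon. Without any measured step of this kind to lean on, the change from compound 2 to compound 3 is expected to bring at most a modest weakening, likely within or near the scatter. Compound 3 is therefore estimated at 700 nM in this assay, with a range from 200 nM to 3000 nM, and the step of a 1.4-fold higher number from compound 2 to compound 3 (0.16 log units; within the scatter) is the expected shift.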

Compound 3, half-maximal inhibitory concentration: 42 nM
Estimate against measurement, compound 3: 17-fold (1.22 log units) above, outside the stated range (below it).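

At this aromatic carbon of the five-membered aromatic ring, the group matters strongly in this assay: replacing benzyl with the group holding a five-membered aromatic ring and a six-membered non-aromatic ring gives a 12-fold lower number from compound 2 to compound 3 (1.07 log units; beyond the scatter). This is the first single-place step shown, and it establishes that benzyl is not needed here.

As far as these compounds go, whether a plain piperidine or morpholine at this carbon would match the gain remains open. Compound 1 offers no comparison, since its value is only a limit: the limit of > 1000 nM in this assay, at which 1 of the 3 values shown sits.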